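The source may hold more compounds than are shown below. What is called first, only, known or untested is meant among the compounds shown, and "the series" means these compounds.

Measured compounds:
- compound 1, `O=C(CSc1nc(Nc2ccccc2)c2ccccc2n1)Nc1ccccc1Br`, 18600 nM in a functional assay on MGC-803 cells (Homo sapiens) for inhibition, read by MTT assay, with a stated time of 72 h; on this read-out lower numbers stand for stronger inhibition and higher numbers for weaker inhibition
- compound 2, `C=CC(=O)Nc1cccc(NC(=O)CSc2nc(Nc3ccccc3Cl)c3ccccc3n2)c1`, 20700 nM

Both compounds share the same core and differ in the side groups. Compound 1 carries a bromine on the amide-bound ring and an unsubstituted ring on the amine; compound 2 carries an acrylamide on the amide-bound ring and a 2-chlorophenyl on the amine. In this assay compound 2 and compound 1 give numbers that lie within the usual scatter of each other, so neither can be called the stronger inhibitor of the two on this evidence.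

Compound 3, `C=CC(=O)Nc1cccc(NC(=O)CSc2nc(Nc3cccc(Cl)c3)c3ccccc3n2)c1`, has not yet been measured. It keeps everything in compound 2 except one change: 3-chlorophenyl in place of 2-chlorophenyl on a nitrogen on an aromatic ring. The chlorine thus sits at a different position on the same ring. Within the data shown here, no measured pair shows what such a move does here, so the size of the step is unknown. With no guide from the data, the step is expected to be small, without a set direction, and likely within the scatter: a 1.2-fold lower number from compound 2 to compound 3 (0.06 log units; within the scatter). In this assay compound 3 is therefore expected to give about 18000 nM, with a range from 6000 nM to 55000 nM.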

Compound 3, half-maximal inhibitory concentration: 7830 nM
Compound 3: middle estimate off by 2.3-fold (0.36 log units), on the high side; the measured number falls inside the stated range.
By their numbers in this assay, from the lowest: compound 3; then compounds 1 and 2 (each within the scatter of the next).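

In this assay, putting 3-chlorophenyl in place of 2-chlorophenyl on a nitrogen on an aromatic ring gives a 2.6-fold lower number from compound 2 to compound 3 (0.42 log units; beyond the scatter). The two compounds have the same atoms, joined differently, so this step shows that the place of the chlorine on this ring alone can shift the number by more than the usual scatter, although the shift is modest. Compounds 1 and 2 could not show this, as they differ in more than one place; nothing measured here explains why the move changes the number.

Going by these compounds, it remains open whether the chlorine itself matters at this ring, or whether another group such as a bromine or a methoxy group, or a plain phenyl with the acrylamide kept, would give a similar number. The part played by the acrylamide is also open: no pair shown changes that group alone, so what a propanamide in its place would do in this assay cannot be read from these compounds.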